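The source may report more compounds than this note shows. Statements on the series, on what has been measured and on what is new or still open speak of the compounds shown alone.

Measured so far in a functional assay on MCF7 cells (Homo sapiens) for inhibition, read by sulforhodamine B assay; a higher number here means a weaker inhibitor, a lower number a stronger inhibitor:
- Compound 1 `O=C1C(Nc2ccccc2)=CC(=O)c2c1nc1n2[C@H]2OC[C@@H](O)[C@H]2OC1`: > 4000 nM
- Compound 2 `Cc1ccc(NC2=CC(=O)c3c(nc4n3[C@H]3OC[C@@H](O)[C@H]3OC4)C2=O)cc1`: > 4000 nM

Neither entry is a number. In this assay, compound 2 stands only at a limit, > 4000 nM. Compound 1 likewise gives only a limit, > 4000 nM. Both compounds therefore sit together at one boundary: the limit of > 4000 nM in this assay, at which 2 of the 2 values shown sit.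

For the measured compounds named here, the one measured step, a step that the two limits leave unreadable from compound 1 to compound 2, places methyl in place of hydrogen on an aromatic carbon. It offers no size to carry forward.

Compound 3 `COc1ccccc1NC1=CC(=O)c2c(nc3n2[C@H]2OC[C@@H](O)[C@H]2OC3)C1=O` has 2-methoxyphenyl in place of 4-methylphenyl on an amine nitrogen. This change has not been tested on any measured pair, so its effect cannot be read from the data. The expectation rests solely on the position of compound 1 and compound 2 at the limit of > 4000 nM in this assay, at which 2 of the 2 values shown sit. No step beyond the scatter is expected in this assay, in either direction, and a further reading at the limit is quite likely. The expected step is a number no higher from compound 2 to compound 3 (the limit leaves the size open). The estimate for compound 3 is 4000 nM, with an expected range from 1500 nM to 10000 nM.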

Compound 3, half-maximal inhibitory concentration: 6580 nM
Compound 3: the middle estimate sits 1.6-fold (0.22 log units) below what was measured, and the stated range covers the measured number.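

In this assay compound 3 gives 6580 nM. No step from compound 1 or compound 2 to compound 3 can be read, because both of those compounds give only a limit: the limit of > 4000 nM in this assay, at which 2 of the 3 values shown sit.

The compounds shown leave open whether any of the groups on the amine nitrogen changes the inhibition of these cells beyond the usual scatter.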